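Notes on Three Measured Thioether Analogues and One Untested

A few compounds are considered here, and "the series" means these few. Any claim that something is new, unique, unknown or untested is made for them only; others in the source may bear on it.

Compound 1, `Cc1cc(Nc2ccn(Cc3ccccc3)n2)n2nc(SCc3ccc(Br)cc3)nc2n1`, gives 15800 nM in a functional assay on MCF7 cells (Homo sapiens) for inhibition, read by MTT assay, with a stated time of 72 h; a higher number here means a weaker inhibitor, a lower number a stronger inhibitor. Compound 2, `Cc1cc(Nc2cc(-c3ccccc3)[nH]n2)n2nc(SCc3cccc(Br)c3)nc2n1`, gives 5140 nM in this assay. Compound 3, `Cc1cc(Nc2ccn(Cc3ccc(F)cc3)n2)n2nc(SCc3ccc(Br)cc3)nc2n1`, gives 4280 nM in this assay.

Compound 2 stands second highest of the three numbers; its value and that of compound 3 lie within the scatter of each other, while compound 1 sits higher beyond the scatter. Compound 4, `Cc1cc(Nc2cc(-c3ccccc3)[nH]n2)n2nc(SCc3cccc4ccccc34)nc2n1`, differs from compound 2 by naphthalen-1-yl in place of 3-bromophenyl on a saturated chain carbon bound to a sulfur. Among the measured compounds shown here, the only measured step, a 3.7-fold lower number from compound 1 to compound 3 (0.57 log units; beyond the scatter), concerns fluoro in place of hydrogen on the benzyl attached to the ring nitrogen, a different change at a different place, and does not bear on this exchange. For the measured compounds named here, no measured step covers the exchange here, so no step beyond the scatter is expected in either direction. Compound 4 is therefore estimated at 4500 nM, with a range of 1500 nM to 14000 nM, which means an expected step of a 1.1-fold lower number from compound 2 to compound 4 (0.06 log units; within the scatter).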

Compound 4, half-maximal inhibitory concentration: 7560 nM
The estimate for compound 4 lay 1.7-fold (0.23 log units) below the measured number; the measured number falls inside the stated range.
By their numbers in this assay, from the lowest: compounds 3, 2 and 4 (each within the scatter of the next); then compound 1.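

In this assay, naphthalen-1-yl in place of 3-bromophenyl on a saturated chain carbon bound to a sulfur gives a 1.5-fold higher number from compound 2 to compound 4 (0.17 log units; within the scatter). Among the compounds shown here, this is the first step read at this place, and it shows that the bromine can leave and the group can grow from 7 to 10 heavy atoms with no step beyond the scatter. Nothing at hand explains this result.

Open, on these data alone, is whether a group of another kind at this place, such as an amine or a carboxylic acid, would give a step beyond the scatter. One pair also leaves open whether the same exchange reads alike in the setting of compound 3.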